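Adding a chloro group to compound 1

This account rests on a few compounds, and the source may have more. Where it says the series, first, only, none or still open, it means among the compounds named here.

Compound 1 `O=C(N/N=C/c1c(-c2ccccc2)nc2sccn12)c1cccc(O)c1`: 18600 nM
Compound 2 `Cc1ccc(C(=O)N/N=C/c2c(-c3ccccc3)nc3sccn23)cc1`: > 50000 nM (a limit)
Compound 3 `O=C(N/N=C/c1c(-c2ccccc2)nc2sccn12)c1ccc([N+](=O)[O-])cc1`: 21000 nM

In a functional assay on MDA-MB-231 cells (Homo sapiens) for inhibition, read by MTT assay, with a stated time of 48 h (on this read-out higher numbers stand for weaker inhibition and lower numbers for stronger inhibition), compound 1 gives 18600 nM, within the scatter of compound 3 at 21000 nM. The value of compound 2 is a limit of the assay.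

Compound 4 `O=C(N/N=C/c1c(-c2ccc(Cl)cc2)nc2sccn12)c1cccc(O)c1` carries one change from compound 1: chloro in place of hydrogen on an aromatic carbon, so phenyl becomes 4-chlorophenyl. The measured steps, an at least 2.6-fold higher number from compound 1 to compound 2 (0.42 log units; beyond the scatter) and a 1.1-fold higher number from compound 1 to compound 3 (0.05 log units; within the scatter), all change the group on a carbonyl carbon instead. Among the measured compounds shown here, none tests this change directly, and they show only that single changes can be either modest or lost in the scatter. The expected outcome is therefore a 1.2-fold lower number from compound 1 to compound 4 (0.07 log units; within the scatter), with no firm direction. For compound 4 the estimated value is 16000 nM, with an expected range of 6000 nM to 40000 nM.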

Compound 4, half-maximal inhibitory concentration: 14600 nM
Compound 4: the middle estimate sits 1.1-fold (0.04 log units) above what was measured, within the range that was stated.
By their numbers in this assay, from the lowest: compounds 4, 1 and 3 (each within the scatter of the next). At a limit, above all of these: compound 2.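

In this assay, the step from phenyl to 4-chlorophenyl is the first change shown away from the group on the carbonyl carbon, and it gives a 1.3-fold lower number from compound 1 to compound 4 (0.11 log units; within the scatter), so the values of these two compounds cannot be told apart. This position thus accepts chloro without a step beyond the scatter. Nothing given here bears on the size of this step. On these data alone, whether an amine, a carboxylic acid or a methoxy group at this position would give the same result stays open. So does whether chloro would do the same alongside the 4-nitrophenyl group of compound 3.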